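Swapping the Benzyloxy Group on the Chloro Series

This account rests on a few compounds, and the source may have more. Where it says the series, first, only, none or still open, it means among the compounds named here.

Compound 1 `Cc1ccc(NC(=S)NC(=O)c2ccc(OCc3ccc(C(F)(F)F)cc3)cc2)cc1-c1nc2ccccc2[nH]1`: 17600 nM
Compound 2 `Cc1ccc(NC(=S)NC(=O)c2ccc(OCc3ccc(Cl)cc3Cl)cc2)cc1-c1nc2ccccc2[nH]1`: 11600 nM
Compound 3 `O=C(NC(=S)Nc1ccc(Cl)c(-c2nc3ccccc3[nH]2)c1)c1ccc(OCc2ccc(C(F)(F)F)cc2)cc1`: 12900 nM

All three numbers come from a functional assay on HT-29 cells (Homo sapiens) for inhibition, read by MTT assay, with a stated time of 48 h; on this read-out higher numbers stand for weaker inhibition and lower numbers for stronger inhibition. Compound 3 lies within the scatter of both compound 2 and compound 1, so the three cannot be told apart on these numbers. Compound 4, `O=C(NC(=S)Nc1ccc(Cl)c(-c2nc3ccccc3[nH]2)c1)c1ccc(OCc2ccc(Cl)cc2Cl)cc1`, differs from compound 3 in one place: 2,4-dichlorophenyl in place of 4-(trifluoromethyl)phenyl on a saturated chain carbon bound to an oxygen on an aromatic ring. The same exchange has been measured once, on the methyl-bearing core, where it gave a 1.5-fold lower number from compound 1 to compound 2 (0.18 log units; within the scatter), a step within the scatter. The other measured step, a 1.4-fold lower number from compound 1 to compound 3 (0.13 log units; within the scatter), was likewise within the scatter. Compound 4 is therefore expected to sit close to compound 3, with a step of a 1.4-fold lower number from compound 3 to compound 4 (0.13 log units; within the scatter) that does not exceed the scatter. The estimate for compound 4 in this assay is 9500 nM, within 4500 nM to 20000 nM.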

Compound 4, half-maximal inhibitory concentration: 6080 nM
Compound 4: middle estimate off by 1.6-fold (0.19 log units), on the high side; low and high end bracket the measured number.
By their numbers in this assay, from the lowest: compounds 4, 2, 3 and 1 (each within the scatter of the next, the first and the last beyond it).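

On the core of compound 3, 2,4-dichlorophenyl in place of 4-(trifluoromethyl)phenyl gives a step that clears the scatter in this assay, a 2.1-fold lower number from compound 3 to compound 4 (0.33 log units; beyond the scatter), though it remains in line with the step on the core of compound 1: the same change on two cores in this assay, a 1.5-fold lower number (0.18 log units; within the scatter) from compound 1 to compound 2 and a 2.1-fold lower number (0.33 log units; beyond the scatter) from compound 3 to compound 4, 1.4-fold (0.15 log units) apart, within the scatter of two such steps. Chloro in place of methyl on an aromatic carbon gives a 1.9-fold lower number from compound 2 to compound 4 (0.28 log units; within the scatter), so it stays within the scatter on this second pair as well: the same change on two cores in this assay, a 1.4-fold lower number (0.13 log units; within the scatter) from compound 1 to compound 3 and a 1.9-fold lower number (0.28 log units; within the scatter) from compound 2 to compound 4, 1.4-fold (0.15 log units) apart, within the scatter of two such steps.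

The compounds shown leave open how 4-chlorophenyl, 2-chlorophenyl or a pyridine ring would compare at this place. They also leave open how bromo or methoxy would compare with chloro and methyl on the aromatic carbon.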